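This account rests on a few compounds, and the source may have more. Where it says the series, first, only, none or still open, it means among the compounds named here.

In a functional assay on HeLa cells (Homo sapiens) for cytotoxicity, read by MTT assay, with a stated time of 24 h (on this read-out higher numbers stand for weaker inhibition and lower numbers for stronger inhibition), compound 1 `C[C@H]1O[C@]1(C)C(=O)C[C@@H]1[C@@]2(C)[C@@H](O)CCC(C)(C)[C@]2(O)CC[C@@]1(C)O` gives > 10000 nM, which is a limit of the assay and not a number. Compound 2 `C[C@@H]1O[C@@]1(C)C(=O)C[C@H]1[C@](C)(O)CC[C@@]2(O)C(C)(C)CCC[C@]12C` gives > 10000 nM, which is also a limit and not a number. Compound 2 therefore has no exact position on this scale, and the limit of > 10000 nM in this assay, at which 2 of the 2 values shown sit, shows that both measured compounds share this limit.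

Compound 3 `C[C@H]1O[C@]1(C)C(=O)C[C@H]1[C@](C)(O)CC[C@@]2(O)C(C)(C)CCC[C@]12C` has not yet been measured. It is related to compound 2 as follows: the two compounds have the same atoms and bonds and differ only in configuration as drawn: 2 of 6 stereo elements differ; a stereocentre at a saturated ring carbon is drawn S in compound 2 and R in compound 3; a stereocentre at a saturated ring carbon is drawn R in compound 2 and S in compound 3. Going by the values given here, no measured step shows what such a change in configuration does in this assay. The expectation therefore rests on compound 2, whose > 10000 nM is a limit. The expected step that the limit leaves unreadable from compound 2 to compound 3 is no shift beyond the usual scatter, in neither direction. For compound 3 the estimated value is 15000 nM, with an expected range from 6000 nM to 40000 nM.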

Compound 3, half-maximal inhibitory concentration: > 10000 nM
Compound 3 ended at the assay's limit; the forecaster's own chance of this, stated with the estimate: 75%; the middle value is on the limit's open side.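

In this assay compound 3 gives > 10000 nM, a limit and not a number. Its steps from compound 1 and compound 2 therefore cannot be read. The compounds shown leave open whether the configuration or hydrogen in place of hydroxy on a saturated ring carbon affects activity at all.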